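The source may hold more compounds than are shown below. What is called first, only, known or untested is meant among the compounds shown, and "the series" means these compounds.

Measured so far:
compound 1, `CC(=O)NCCN(C)c1cccc(OCCCCN)c1`: 12900 nM
compound 2, `CC(=O)NCCN(C)c1cccc(OCCCCCCNC(=O)Oc2cccc(-c3ccccc3)c2)c1`: 33.1 nM
compound 3, `CC(=O)NCCN(C)c1cccc(OCCCCCCCCNC(=O)Oc2cccc(-c3ccccc3)c2)c1`: 32.4 nM

In an assay on cells for displacement of a labelled ligand from melatonin receptor type 1B (Homo sapiens), using the Cheng-Prusoff equation, with a stated time of 90 min (a higher number here means a weaker inhibitor, a lower number a stronger inhibitor), compound 1 gives 12900 nM, the highest number of the three. Compound 2 gives 33.1 nM and compound 3 gives 32.4 nM; both of these numbers lie far below that of compound 1, beyond the scatter, while the two of them sit within the scatter of each other. Going by the values given here, no single-point step connects compound 1 to either of them, so the account rests on the values alone: the two compounds that carry a ring-bearing end group on the chain show much lower numbers than compound 1, which ends in a free amine.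

Compound 4, `CC(=O)NCCN(C)c1cccc(OCCCCOc2cccc(O)c2)c1`, keeps the core of compound 1 and changes the chain end: 3-hydroxyphenoxy in place of amino on a saturated chain carbon, four bonds along the chain from an oxygen on an aromatic ring. Among the compounds with values here, no measured step covers exactly this change. Given the contrast between compound 1 at 12900 nM and the ring-capped compounds 2 and 3, a large downward step in this assay is expected, though smaller than the gap those two compounds show, since compound 4 carries a shorter chain and a different end group. The step from compound 1 to compound 4 is expected to be a 22-fold lower number from compound 1 to compound 4 (1.33 log units; beyond the scatter). Compound 4 is estimated at 600 nM, with a range from 100 nM to 3500 nM.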

Compound 4, inhibition constant: 603 nM
The estimate for compound 4 lay 1.0-fold (0.00 log units) below the measured number; the measured number falls inside the stated range.
By their numbers in this assay, from the lowest: compounds 3 and 2 (each within the scatter of the next); then compound 4; then compound 1.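

Replacing amino with 3-hydroxyphenoxy on a saturated chain carbon, four bonds along the chain from an oxygen on an aromatic ring, gives in this assay a 21-fold lower number from compound 1 to compound 4 (1.33 log units; beyond the scatter), the first change confined to one place among the compounds shown. The earlier contrast between compound 1 and the two compounds with longer chains involved both chain length and end group, so it could not be assigned to either one; here the shared core and the chain stay the same, which shows that the end group alone moves the number well beyond the scatter. Nothing measured here explains why this exchange lowers the number.

The compounds shown leave open whether the hydroxyl on the new ring takes part in this step, since a plain phenoxy group or a methoxy-bearing phenoxy group at the same place would be needed to separate the ring from its hydroxyl. They also leave open how the number would respond if 3-hydroxyphenoxy sat on a longer chain, with only the chain changed from compound 4.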